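This account rests on a few compounds, and the source may have more. Where it says the series, first, only, none or still open, it means among the compounds named here.

Values in a functional assay on MDA-MB-231 cells (Homo sapiens) for inhibition, read by MTT assay, with a stated time of 48 h (a higher number here means a weaker inhibitor, a lower number a stronger inhibitor), for the series so far
- compound 1 `COc1ccc(-c2cc(-c3cc(OC)c(OC)c(OC)c3)nc(-c3ccccc3)n2)cc1` gives 3390 nM
- compound 2 `COc1cc(-c2cc(-c3ccc(O)cc3)nc(-c3ccccc3)n2)cc(OC)c1OC` gives 1600 nM
- compound 3 `COc1cc(-c2cc(-c3ccc(O)cc3O)nc(-c3ccccc3)n2)cc(OC)c1OC` gives 810 nM

Compound 3 stands level with compound 2, since a 2.0-fold lower number from compound 2 to compound 3 (0.30 log units; within the scatter) stays within the scatter, and clear of compound 1, since a 4.2-fold lower number from compound 1 to compound 3 (0.62 log units; beyond the scatter) lies beyond it. Compound 4 `COc1cc(-c2cc(-c3cccc4ccccc34)nc(-c3ccccc3)n2)cc(OC)c1OC` carries naphthalen-1-yl in place of 2,4-dihydroxyphenyl on an aromatic carbon. Among the measured compounds shown here, no measured compound holds naphthalen-1-yl, so the evidence is indirect. The nearest guide is a 2.1-fold lower number from compound 1 to compound 2 (0.33 log units; beyond the scatter), a modest step that comes with a free hydroxy group, and compound 4 has none. A modest rise in this assay is therefore expected, with wide uncertainty. The expected change is a 3.1-fold higher number from compound 3 to compound 4 (0.49 log units; beyond the scatter). Compound 4 is estimated at 2500 nM, with an expected range from 800 nM to 8000 nM.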

Compound 4, half-maximal inhibitory concentration: 3240 nM
The estimate for compound 4 lay 1.3-fold (0.11 log units) below the measured number; low and high end bracket the measured number.
By their numbers in this assay, from the lowest: compounds 3 and 2 (each within the scatter of the next); then compounds 4 and 1 (each within the scatter of the next).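

In this assay naphthalen-1-yl, with no hydrogen-bond donors, loses ground at this position against both aryl groups that carry a free hydroxy group (a 4.0-fold higher number from compound 3 to compound 4 (0.60 log units; beyond the scatter); a 2.0-fold higher number from compound 2 to compound 4 (0.31 log units; beyond the scatter)). Against 4-methoxyphenyl it shows no separation (a 1.0-fold lower number from compound 1 to compound 4 (0.02 log units; within the scatter)), so the two aryl groups without a hydroxy group read alike here. No evidence bearing on the cause of these steps is available. Open, on these data alone, is whether a hydroxy group is specifically required at this position. An amine or a carboxylic acid on the phenyl ring could test this.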